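The compounds below may be only part of what the source reports. "The series", "measured", "known", "first", "only" and "open" are said of these compounds alone.

Of the compounds shown here, three with a shared core have been tested in a functional assay on HCT-15 cells (Homo sapiens) for cytotoxicity; a lower number here means that less compound is tolerated, a higher number that more compound is tolerated. Compound 1, `COc1cccc(-c2nn(-c3ccccc3)cc2-c2ccnc(NCCNC(=O)Nc3cccc(C(F)(F)F)c3)c2)c1`, gives 100000 nM in this assay. Compound 2, `COc1cccc(-c2nn(-c3ccccc3)cc2-c2ccnc(NCCCNC(=O)Nc3ccc(Cl)c(Cl)c3)c2)c1`, gives 29100 nM. Compound 3, `O=C(NCCCNc1cc(-c2cn(-c3ccccc3)nc2-c2cccc(O)c2)ccn1)c1ccccc1`, gives 100000 nM. On these numbers compound 3 stands level with compound 1 at the digits shown, the two together being the highest of the three, and its nearest neighbour is therefore compound 1 with no change within the scatter. Its furthest neighbour is compound 2, whose number is lower by a margin that lies beyond the scatter.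

Compound 4, `O=C(NCCCNc1cc(-c2cn(-c3ccccc3)nc2-c2cccc(O)c2)ccn1)c1ccc(F)cc1`, differs from compound 3 in one place: fluoro in place of hydrogen on an aromatic carbon. The benzoyl group of the amide becomes a (4-fluorophenyl)carbonyl group, and nothing else in the molecule moves. Within the data shown here, no measured pair in this set shows what such a change does here, so the expectation rests on the small size of the change alone.

The step of a 1.1-fold lower number from compound 3 to compound 4 (0.05 log units; within the scatter) is expected to stay within the scatter, with no direction claimed. Compound 4 is accordingly estimated to give 90000 nM in this assay, with a range from 40000 nM to 100000 nM.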

Compound 4, concentration lethal to 50% of the cells: 8090 nM
Estimate against measurement, compound 4: 11-fold (1.05 log units) above; measured number outside the range, below it.
By their numbers in this assay, from the lowest: compound 4; then compound 2; then compounds 1 and 3 (each within the scatter of the next).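

In this assay, the step of a 12-fold lower number from compound 3 to compound 4 (1.09 log units; beyond the scatter) shows that this carbon of the benzoyl group is not indifferent to substitution: one fluoro in place of hydrogen, para to a large group, moves the number well beyond the scatter, and towards less compound being tolerated. Among these compounds, this is the first comparison in the set in which only one place differs, so the earlier compounds could show differences only between molecules that differ in several places at once, whereas here the whole step belongs to a change of one heavy atom. Nothing available for this set accounts for so large a step from so small a change.

The compounds shown leave open whether this step is particular to fluoro or would also appear with chloro, methoxy or an amine on the same aromatic carbon. They also leave open whether the same fluoro would have a comparable effect at another carbon of that ring, or in a compound with a longer chain between the amide and the shared core.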